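Fluoro on the benzamido ring across two related cores

A few compounds are considered here, and "the series" means these few. Any claim that something is new, unique, unknown or untested is made for them only; others in the source may bear on it.

Measured in a functional assay on Raji cells (Homo sapiens) for antiproliferative activity, read by CCK-8 assay, with a stated time of 72 h, tested at 40 uM (on this read-out lower numbers stand for less inhibition and higher numbers for more inhibition at the one concentration tested (going by the name of the read-out)), so far:
compound 1, `CCOC(=O)c1sc(-c2cccc(NC(=O)c3ccccc3)c2)nc1Nc1ccc(N2CCN(C)CC2)cc1`: 42%
compound 2, `CCOC(=O)c1sc(-c2cccc(NC(=O)c3ccccc3F)c2)nc1Nc1ccc(N2CCN(C)CC2)cc1`: 89.8%
compound 3, `CN1CCN(c2ccc(Nc3nc(-c4cccc(NC(=O)c5ccccc5)c4)sc3C(N)=O)cc2)CC1`: 91.3%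

Compound 2 differs from compound 1 by fluoro in place of hydrogen on an aromatic carbon, and the step in this assay is a number 47.8 percentage points higher from compound 1 to compound 2 (beyond the scatter). Compound 3 carries a different core; it differs from compound 1 by amino in place of ethoxy on a carbonyl carbon, a step of a number 49.3 percentage points higher from compound 1 to compound 3 (beyond the scatter). Compound 2 and compound 3 stand within the scatter of each other, so no order between them is read.

Compound 4, `CN1CCN(c2ccc(Nc3nc(-c4cccc(NC(=O)c5cccc(F)c5)c4)sc3C(N)=O)cc2)CC1`, is not yet measured. It differs from compound 3 by fluoro in place of hydrogen on an aromatic carbon. Going by the values given here, this is the same kind of change as the one from compound 1 to compound 2, not the same change: in compound 2 the fluorine sits ortho to a large group, in compound 4 meta to a large group.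

For compound 4 a step of a number 1.7 percentage points higher from compound 3 to compound 4 (within the scatter) is expected, far smaller than the earlier step, because compound 3 already stands at 91.3% and the read-out cannot rise much further. Compound 4 is estimated at 93%, expected between 84% and 99%.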

Compound 4, a percentage reported as inhibition, at one concentration (the size of the read-out at that concentration, not a potency): 2.78%
For compound 4 the middle estimate is 90.2 percentage points above the measured one; measured number below the stated range.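

On the core of compound 3, fluoro in place of hydrogen on an aromatic carbon gives a number 88.5 percentage points lower from compound 3 to compound 4 (beyond the scatter) in this assay. Set beside the earlier step, the effect of this kind of change does not carry from one core to the other, and even its direction reverses: the same change on two cores in this assay, a number 47.8 percentage points higher (beyond the scatter) from compound 1 to compound 2 and a number 88.5 percentage points lower (beyond the scatter) from compound 3 to compound 4, 136.3 percentage points apart, beyond the scatter of two such steps What this does not show is whether the core or the place of the fluoro on the ring decides the outcome: the two pairs differ in both, and these compounds give no reason for the fall.

Open, from the compounds shown here alone, is how the 3-fluorophenyl group behaves on the core of compound 1, and how the ring of compound 2 behaves on the core of compound 3, the two pairings that would separate core from place. Also open, going by these compounds, is whether a chloro or methoxy group at the place of the fluoro in compound 4 gives a similar fall, or whether it is confined to fluoro.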